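Working notes: from compound 3 to compound 4

The source may hold more compounds than are shown below. What is called first, only, known or untested is meant among the compounds shown, and "the series" means these compounds.

Values measured in an ADME assay on L02 cells (Homo sapiens) for cytotoxicity, read by MTT assay, with a stated time of 72 h (a higher number here means a weaker inhibitor, a lower number a stronger inhibitor), are as follows
- Compound 1 `C=CC(=O)Nc1cccc(Oc2nc(Nc3ccn(C)n3)nc3c2CSCC3)c1` gives > 50000 nM as a limit
- Compound 2 `C/C=C/C(=O)Nc1cccc(Oc2nc(Nc3ccn(C)n3)nc3c2CSCC3)c1` gives > 50000 nM as a limit
- Compound 3 `CCC/C=C/C(=O)Nc1cccc(Oc2nc(Nc3ccn(C)n3)nc3c2CSCC3)c1` gives > 50000 nM as a limit

Compound 3 has no number, only the limit > 50000 nM and nothing finer. Going by the values given here, the series so far offers a single reading: the limit of > 50000 nM in this assay, at which 3 of the 3 values shown sit, and no more.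

Compound 4 `CC(C)/C=C/C(=O)Nc1cccc(Oc2nc(Nc3ccn(C)n3)nc3c2CSCC3)c1` keeps the shared core and the amide, and carries isopropyl in place of propyl on a double-bonded chain carbon bound to a double-bonded chain carbon. The measured steps that bear on this are a step that the two limits leave unreadable from compound 2 to compound 3 and a step that the two limits leave unreadable from compound 1 to compound 3 and also a step that the two limits leave unreadable from compound 1 to compound 2 and none of them has a size to carry over. Going by a step that the two limits leave unreadable from compound 2 to compound 3 no step beyond the scatter is expected in this assay in either direction. The estimate of the change is a number no higher from compound 3 to compound 4 (the limit leaves the size open) as an expectation only. For compound 4 the expected value is 50000 nM with an estimated range of 30000 nM to 90000 nM and another report as a limit is likely.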

Compound 4, half-maximal inhibitory concentration: > 50000 nM
Compound 4: a limit, no number (the forecaster's own chance of this, stated with the estimate: 90%); the middle value lies on the limit itself.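

In this assay compound 4 is also reported only as a limit, and no step to it from compound 1, compound 2 or compound 3 can be read: the limit of > 50000 nM in this assay, at which 4 of the 4 values shown sit.

The compounds shown leave open whether compound 1, compound 2, compound 3 and compound 4 differ at all in this assay.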